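Replacing methyl with methoxy at one aromatic position

The source may report more compounds than this note shows. Statements on the series, on what has been measured and on what is new or still open speak of the compounds shown alone.

In a functional assay on HSC-2 cells (Homo sapiens) for cytotoxicity, with a stated time of 24 h (a higher number here means that more compound is tolerated, a lower number that less compound is tolerated), compound 1 `O=C1/C(=C/c2ccc(Cl)cc2)CCC/C1=C\c1ccc([N+](=O)[O-])cc1` gives 1500 nM and compound 2 `Cc1ccc(/C=C2\CCC/C(=C\c3ccc([N+](=O)[O-])cc3)C2=O)cc1` gives 6600 nM as its half-maximal cytotoxic concentration, so compound 2 holds the higher of the two numbers. Compound 3 `COc1ccc(/C=C2\CCC/C(=C\c3ccc([N+](=O)[O-])cc3)C2=O)cc1` shares the core of compound 2 and differs from it in one place: methoxy in place of methyl on an aromatic carbon with methoxy in place of methyl on an aromatic carbon, para to a large group. Among the compounds with values here, only one measured step bears on this change. That step is a 4.4-fold higher number from compound 1 to compound 2 (0.64 log units; beyond the scatter) and it came with methyl in place of chloro on an aromatic carbon. It is modest but beyond the scatter, and it shows that the number can respond to a swap of this kind. Within the data shown here, no measured compound carries methoxy, so the step gives neither a firm size nor a firm direction. A smaller step than that one is expected in this assay with only a slight lean towards a lower number. The estimated change is a 1.3-fold lower number from compound 2 to compound 3 (0.12 log units; within the scatter) for this swap. For compound 3 the estimated value is 5000 nM within an expected range of 1700 nM to 15000 nM in this read-out.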

Compound 3, half-maximal cytotoxic concentration: > 400000 nM
Compound 3 was reported as a limit (the forecaster's own chance of this, stated with the estimate: 3%); middle value at least 80-fold (1.90 log units) away from the limit.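

In this assay, within the data shown here, the aromatic carbon para to a large group proves far more sensitive than the single earlier step, a 4.4-fold higher number from compound 1 to compound 2 (0.64 log units; beyond the scatter), could show. Methoxy in place of methyl gives an at least 60-fold higher number from compound 2 to compound 3 (1.78 log units; beyond the scatter), and methoxy in place of chloro gives an at least 260-fold higher number from compound 1 to compound 3 (2.42 log units; beyond the scatter), so both steps into compound 3 are large where the step between the other two compounds is modest. The value of compound 3 is a limit and not a number, so these two steps fix only a floor and not a size: the limit of > 400000 nM in this assay, at which 1 of the 3 values shown sits.

The compounds shown leave open whether the oxygen or the methoxy group as a whole carries this jump, a question on which a hydroxyl, an ethoxy or a dimethylamino group at the same place would bear. They also leave open whether methoxy in place of methyl gives a step of this kind when an amine stands in place of the nitro group of the shared core.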